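The source may report more compounds than this note shows. Statements on the series, on what has been measured and on what is new or still open speak of the compounds shown alone.

Compound 1 `CC(C)c1onc(-c2c(Cl)cccc2Cl)c1COc1ccc(-c2nc3ccc(C(=O)O)cc3n2CC(C)(C)C)cc1`: 13 nM
Compound 2 `CCCC(CCC)n1c(-c2ccc(OCc3c(-c4c(Cl)cccc4Cl)noc3C(C)C)cc2)nc2ccc(C(=O)O)cc21`: 1.8 nM
Compound 3 `CC(=O)N1CCC(n2c(-c3ccc(OCc4c(-c5c(Cl)cccc5Cl)noc4C(C)C)cc3)nc3ccc(C(=O)O)cc32)CC1`: 1430 nM

All three share the same core and differ only in the group on the aromatic nitrogen, and all were tested in an assay on Huh-7 cells for agonist activity at Bile acid receptor (Homo sapiens), read by a luciferase reporter; a lower number here means that less compound is needed, a higher number that more compound is needed for the effect. Compound 1 stands second highest of the three numbers. Compound 2 is nearest, with a 7.2-fold lower number from compound 1 to compound 2 (0.86 log units; beyond the scatter), and compound 3 is furthest, with a 110-fold higher number from compound 1 to compound 3 (2.04 log units; beyond the scatter). The gap between the other two is wider still: a 790-fold higher number from compound 2 to compound 3 (2.90 log units; beyond the scatter).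

Compound 4 `CC(=O)C1CCC(Cn2c(-c3ccc(OCc4c(-c5c(Cl)cccc5Cl)noc4C(C)C)cc3)nc3ccc(C(=O)O)cc32)CC1` has not yet been measured. It differs from compound 1 as follows: 4-acetylcyclohexyl in place of tert-butyl on a saturated chain carbon bound to an aromatic nitrogen. Cut one bond further out, the same difference reads neopentyl to (4-acetylcyclohexyl)methyl.

Among the measured compounds shown here, two measured steps bear on this change. The step of a 7.2-fold lower number from compound 1 to compound 2 (0.86 log units; beyond the scatter) was modest and downward. The step of a 110-fold higher number from compound 1 to compound 3 (2.04 log units; beyond the scatter) was large and upward. Compound 4 lies between those two cases: it keeps a saturated chain carbon between the new group and the aromatic nitrogen, as in compound 1, and its ring is of carbon only, yet it also carries an acetyl group with one hydrogen-bond acceptor, as does compound 3. A rise in the number beyond the scatter is therefore expected for compound 4, though well short of the step to compound 3. The estimated step is a 4.6-fold higher number from compound 1 to compound 4 (0.66 log units; beyond the scatter). In this assay compound 4 is expected to give 60 nM, within 15 nM to 300 nM.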

Compound 4, half-maximal effective concentration: 1170 nM
For compound 4 the middle estimate is 20-fold (1.29 log units) below the measured one; the measured number lies above the stated range.
By their numbers in this assay, from the lowest: compound 2; then compound 1; then compounds 4 and 3 (each within the scatter of the next).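

Keeping a saturated chain carbon on the aromatic nitrogen and a ring of carbon only did not hold the response in this assay: the change to 4-acetylcyclohexyl gives a 90-fold higher number from compound 1 to compound 4 (1.95 log units; beyond the scatter), and the comparison with the piperidine-containing group gives a 1.2-fold lower number from compound 3 to compound 4 (0.09 log units; within the scatter), so these two acetyl-bearing groups cannot be told apart in this assay. The group without an acetyl, 1-propylbutyl, stands far from the new one, with a 650-fold higher number from compound 2 to compound 4 (2.81 log units; beyond the scatter), and across the four compounds the high numbers occur only with the two acetyl-bearing groups, with no compound shown going against this. Among the compounds shown here, no measurement available here explains why this change moves the number so far.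

The compounds shown leave open whether the shift follows the acetyl group or the larger ring, and a plain cyclohexylmethyl group on the aromatic nitrogen would separate the two. As far as these compounds go, it also remains open whether a hydroxyl, a methyl ester or an amide in place of the acetyl on the cyclohexyl ring would give a number like that of compound 4 or one closer to that of compound 1.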